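The compounds below may be only part of what the source reports. "The series", "measured", "known", "first", "only" and "open" are said of these compounds alone.

Compound 1 `CC(C)OC(=O)C(O)Cn1cnc2c(N)ncnc21` was examined in a functional assay on HeLa cells (Homo sapiens) for cytotoxicity; on this read-out lower numbers stand for higher toxicity in this test and higher numbers for lower toxicity in this test. In this test compound 1 reaches only a limit of the assay, > 400 ug/mL, so no exact number exists for it. Compound 2 `CCCCCOC(=O)C(O)Cn1cnc2c(N)ncnc21` likewise shows only a limit of the assay, > 400 ug/mL. The step that the two limits leave unreadable from compound 1 to compound 2 therefore stays unreadable, since (the limit of > 400 ug/mL in this assay, at which 2 of the 2 values shown sit). Compound 3 `CC(C)COC(=O)C(O)Cn1cnc2c(N)ncnc21` has not been measured yet. It differs from compound 1 as follows: isobutyl in place of isopropyl on an oxygen next to a carbonyl group. Within the data shown here, the one measured step, from compound 1 to compound 2, changes the same oxygen next to a carbonyl group, yet its size cannot be read, so no size of step in this assay can be taken from the data. The expectation is that compound 3 again sits at the limit rather than giving a number. Compound 3 is thus expected at 500 ug/mL, within 250 ug/mL to 1000 ug/mL. The expected step that the limit leaves unreadable from compound 1 to compound 3 is none beyond the scatter.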

Compound 3, minimum cytotoxic concentration: > 400 ug/mL
Compound 3: a limit, no number; the forecaster's own chance of this, stated with the estimate: 85%; the middle value lies beyond the limit too.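

Compound 3, like compound 1 and compound 2, gives only a limit of the assay and no exact number, so the steps among these three compounds cannot be read: the limit of > 400 ug/mL in this assay, at which 3 of the 3 values shown sit. From the compounds shown here alone, what stays open is how the isopropyl, pentyl and isobutyl chains compare in this assay, as none of the three compounds has an exact value there.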